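Replacing a Formyl Group with a Bulky Ester Side Chain

The compounds below may be only part of what the source reports. "The series", "measured", "known", "first", "only" and "open" are said of these compounds alone.

Measured so far:
compound 1, `C=C[C@@](C)(/C=C/c1ccc(O)cc1)CC/C=C(C)/C=C/C(=O)OCc1ccccc1`, > 52000 nM
compound 2, `COc1ccc(/C=C/[C@@](C)(/C=C/c2ccc(O)c(C=O)c2)CCC=C(C)C)cc1`, > 26000 nM

In a functional assay on HepG2 cells (Homo sapiens) for cytotoxicity, with a stated time of 72 h (on this read-out higher numbers stand for an effect only at larger amounts of compound and lower numbers for an effect already at smaller amounts), compound 1 gives > 52000 nM, which is a limit of the assay and not a number. In this assay compound 2 gives > 26000 nM, again a limit rather than a number. For the measured compounds named here, both values known so far are therefore limits: the limit of > 26000 nM in this assay, at which 1 of the 2 values shown sits, and (the limit of > 52000 nM in this assay, at which 1 of the 2 values shown sits). Going by the values given here, compound 2 thus stands at a limit, and no step between two measured compounds can be computed, so nothing is known about how any single change shifts the read-out here.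

Compound 3 `COc1ccc(/C=C/[C@@](C)(/C=C/c2ccc(O)c(/C=C/C(=O)OC(C)(C)C)c2)CCC=C(C)C)cc1` is the next structure to be measured. It differs from compound 2 by 2-(tert-butoxycarbonyl)ethenyl in place of formyl on an aromatic carbon. With both measured compounds at limits, the step from compound 2 to compound 3 is expected to be small or absent beyond the usual scatter, a step that the limit leaves unreadable from compound 2 to compound 3. Compound 3 is therefore expected to give about 30000 nM in this assay, with a likely range from 8000 nM to 100000 nM, and there is a fair chance that only a limit and no number will be reported.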

Compound 3, half-maximal effective concentration: > 52000 nM
Compound 3: a limit, no number (the forecaster's own chance of this, stated with the estimate: 55%); middle value at least 1.7-fold (0.23 log units) from the limit.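

For the compounds shown here, compound 3, like compound 2, gives only a limit of the assay and no number in this assay, and no step from compound 2 to compound 3 can be read. The compounds shown leave open whether 2-(tert-butoxycarbonyl)ethenyl in place of formyl shifts the read-out at all, and at what concentration any of them would show an effect.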